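Hydroxy added to the phenyl group of compound 2

The compounds below may be only part of what the source reports. "The series", "measured", "known", "first", "only" and "open" are said of these compounds alone.

Measured in a functional assay on BT-474 cells (Homo sapiens) for inhibition, read by fluorescence, with a stated time of 72 h; on this read-out lower numbers stand for stronger inhibition of growth and higher numbers for weaker inhibition of growth:
- compound 1 `CC(C)CCn1cnc2c(NCc3cccc(Cl)c3)nc(N[C@H]3CC[C@H](N)CC3)nc21`: 6600 nM
- compound 2 `CC(C)CCn1cnc2c(Nc3ccccc3)nc(N[C@H]3CC[C@H](N)CC3)nc21`: 6400 nM

Going by the values given here, compound 1 and compound 2, the only measured compounds, stand level with each other in this assay, within the scatter. Among the compounds with values here, the single measured step is a 1.0-fold lower number from compound 1 to compound 2 (0.01 log units; within the scatter). It comes with phenyl in place of 3-chlorobenzyl on a nitrogen on an aromatic ring.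

Compound 3 `CC(C)CCn1cnc2c(Nc3cccc(O)c3)nc(N[C@H]3CC[C@H](N)CC3)nc21` keeps everything in compound 2 except for hydroxy in place of hydrogen on an aromatic carbon, meta to a large group: hydroxy in place of hydrogen on an aromatic carbon. The measured step touches the same substituent, but neither measured compound carries a hydroxy, so the data give no direct size for this change. The replacement of a whole group left the number within the scatter, so a similar absence of a clear shift is expected here, with no firm direction. The estimate amounts to a 1.3-fold lower number from compound 2 to compound 3 (0.11 log units; within the scatter), an expected step no larger than the scatter. In this assay compound 3 is expected at 5000 nM, with an estimated range from 1500 nM to 15000 nM.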

Compound 3, concentration for 50% growth inhibition: 14700 nM
The estimate for compound 3 lay 2.9-fold (0.47 log units) below the measured number; the measured number falls inside the stated range.
By their numbers in this assay, from the lowest: compounds 2 and 1 (each within the scatter of the next); then compound 3.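

In this assay, hydroxy in place of hydrogen on an aromatic carbon, meta to a large group, gives a 2.3-fold higher number from compound 2 to compound 3 (0.36 log units; beyond the scatter), a modest step towards weaker inhibition of growth. This position on the phenyl group is therefore not indifferent to change: the exchange of the whole substituent on the nitrogen stayed within the scatter, whereas this single added oxygen moves the number beyond it. Measured against the 3-chlorobenzyl group of the other parent, the 3-hydroxyphenyl group points the same way, with a 2.2-fold higher number from compound 1 to compound 3 (0.35 log units; beyond the scatter). Nothing available here accounts for this shift.

The compounds shown leave open whether the higher number belongs to hydroxy in particular or would also come with a methoxy group, a fluorine atom or an amine on the same aromatic carbon. They also leave open whether hydroxy on another carbon of the phenyl group, or on the ring of the 3-chlorobenzyl group, would give a step of similar direction and size.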